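A few compounds are considered here, and "the series" means these few. Any claim that something is new, unique, unknown or untested is made for them only; others in the source may bear on it.

Measured so far:
compound 1 `CS(=O)(=O)C1(CNCc2ccc(Br)c3cccnc23)CC1` gives 513000000 nM in an assay on isolated protein for displacement of a labelled ligand from 5-hydroxytryptamine receptor 5A (Homo sapiens), read by radioligand binding, with a stated time of 2 h; on this read-out lower numbers stand for stronger inhibition and higher numbers for weaker inhibition
compound 2 `CN(C)S(=O)(=O)CCNCc1ccc(F)c2cccnc12` gives 513000000 nM in this assay

Compound 1 stands level with compound 2 at the digits shown, the two values lying within the scatter of each other. For the measured compounds named here, no step between measured compounds has been worked out. Compound 3 `CS(=O)(=O)C1(CNCc2ccc(Cl)c3cccnc23)CC1` carries the change (chloro in place of bromo on an aromatic carbon), chloro in place of bromo on an aromatic carbon, on the core of compound 1. With both measured compounds giving the same number, no step beyond the scatter is expected in this assay, in either direction. Compound 3 is therefore expected at 513000000 nM, within 200000000 nM to 1300000000 nM, the expected step of no change at the digits printed from compound 1 to compound 3 (within the scatter) being none beyond the scatter.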

Compound 3, half-maximal inhibitory concentration: 525000000 nM
Estimate against measurement, compound 3: 1.0-fold (0.01 log units) below; low and high end bracket the measured number.
By their numbers in this assay, from the lowest: compounds 1, 2 and 3 (each within the scatter of the next).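

In this assay, chloro in place of bromo on an aromatic carbon, para to a large group, gives a 1.0-fold higher number from compound 1 to compound 3 (0.01 log units; within the scatter), so this halogen exchange on the shared core moves the number no further than the scatter. For the compounds shown here, this is the first step read at this position, as the earlier pair offered none. Nothing available accounts for the result.

Going by these compounds, whether a group other than a halogen at this position, such as methoxy or an amine, would shift the number remains open. Also open, on these data alone, is whether a change to the methylsulfonyl cyclopropyl side of the core, such as a carboxylic acid in place of the methylsulfonyl group, would do so.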